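This account rests on a few compounds, and the source may have more. Where it says the series, first, only, none or still open, it means among the compounds named here.

Going by the values given here, in a physicochemical assay for acid dissociation, compound 1 `C=CC(C)(C)OC[n+]1ccn(C)c1/C=N/O` gives 7.94 and compound 2 `CC#CC(C)OC[n+]1ccn(C)c1/C=N/O` gives 8.03 as its reading, so compound 2 stands within the scatter of the only other measured compound. Compound 3 `C#CCC(C)OC[n+]1ccn(C)c1/C=N/O` carries propargyl in place of prop-1-yn-1-yl on a saturated chain carbon bound to an oxygen on a saturated carbon and a saturated chain carbon. Among the compounds with values here, the one measured step (a number 0.09 log units higher from compound 1 to compound 2 (within the scatter)) is likewise an exchange of groups on an oxygen on a saturated carbon, and it stays within the scatter. Within the data shown here, no measured step tests this exact change, so the expectation rests on that single pair. No shift beyond the scatter is expected in this assay here, the estimated step being a number 0.03 log units lower from compound 2 to compound 3 (within the scatter) for this change. The expected value for compound 3 is 8 (estimated range 7.8 to 8.2).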

Compound 3, acid dissociation constant: 8.03
Compound 3: middle estimate off by 0.03 log units, on the low side; the measured number falls inside the stated range.
By their numbers in this assay, from the lowest: compounds 1, 2 and 3 (each within the scatter of the next).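

In this assay, propargyl in place of prop-1-yn-1-yl on a saturated chain carbon bound to an oxygen on a saturated carbon and a saturated chain carbon gives no change at the digits printed from compound 2 to compound 3 (within the scatter), so the place of the triple bond within this group leaves the reading within the scatter. Exchanging the whole group on the oxygen on a saturated carbon, with 1-methylbut-3-yn-1-yl in place of 1,1-dimethylprop-2-en-1-yl, gives a number 0.09 log units higher from compound 1 to compound 3 (within the scatter), which places all three carbon-only groups within the scatter of one another. No supporting information is available to explain these readings.

As far as these compounds go, whether an amine, a carboxylic acid or a longer chain at this place would shift the reading beyond the scatter remains open. From the compounds shown here alone, the effect of a change on the shared core also remains open.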